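This account rests on a few compounds, and the source may have more. Where it says the series, first, only, none or still open, it means among the compounds named here.

Measured so far:
compound 1, `CCn1ncnc1-c1ccccc1NCC1=NCCN1`, in an in vitro functional assay on cells (Fibroblast) for agonist activity at Alpha-1D adrenergic receptor (Homo sapiens) (on this read-out higher numbers stand for an effect only at larger amounts of compound and lower numbers for an effect already at smaller amounts), gives 126 nM
compound 2, `CCCn1ncnc1-c1ccccc1NCC1=NCCN1`, in this assay gives 251 nM
compound 3, `Cn1nccc1-c1ccccc1NCC1=NCCN1`, in this assay gives < 100000 nM

Compound 1 and compound 2 share a core and differ by methyl in place of hydrogen on a saturated chain carbon, two bonds along the chain from an aromatic nitrogen. The step of a 2.0-fold higher number from compound 1 to compound 2 (0.30 log units; within the scatter) is within the usual scatter, so the two values cannot be told apart on this read-out.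

For compound 3 the result in this assay is a limit of the assay, not a number; it is one of the entries described by the limit of < 100000 nM in this assay, at which 1 of the 3 values shown sits. How the core of compound 3 differs from the core of compound 1 is not broken down here.

Compound 4, `CCn1nccc1-c1ccccc1NCC1=NCCN1`, is not yet measured. It differs from compound 3 by methyl in place of hydrogen on a saturated chain carbon bound to an aromatic nitrogen. This is the same kind of change as that from compound 1 to compound 2, but not the same: in the measured pair the methyl enters on a saturated chain carbon two bonds along the chain from an aromatic nitrogen, whereas in compound 4 it enters on a saturated chain carbon bound to an aromatic nitrogen. Going by the values given here, the only measured step of this kind lies within the scatter, so from compound 3 to compound 4 a step that the limit leaves unreadable from compound 3 to compound 4 is expected, and since compound 3 stands only as a limit the expectation is loosely anchored. For compound 4 in this assay a value near 8000 nM is estimated, with the span from 400 nM to 80000 nM, and a fair chance that only a limit is reported again.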

Compound 4, half-maximal effective concentration: < 100000 nM
Compound 4 gave a limit, no number; the forecaster's own chance of this, stated with the estimate: 40%; the middle value does not contradict the limit.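

Compound 3 and compound 4 each stand in this assay only as a limit of the assay, so no step can be read between them: the limit of < 100000 nM in this assay, at which 2 of the 4 values shown sit.

The compounds shown leave open whether methyl in place of hydrogen on a saturated chain carbon bound to an aromatic nitrogen changes the read-out at all, and how the core of compound 4 relates to the core of compound 1 on this read-out.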